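Chain homologation on the shared core: compound 2 to compound 3

The source may hold more compounds than are shown below. What is called first, only, known or untested is meant among the compounds shown, and "the series" means these compounds.

Compound 2 `Nc1ncnc2ncn(CCO)c12` carries a 2-hydroxyethyl chain on the shared core. In a functional assay on CHO cells for antagonist activity at adenosine receptor A2b (Homo sapiens) (a lower number here means a stronger inhibitor, a higher number a weaker inhibitor), compound 2 gives only the limit > 30000 nM. Compound 1 `CC(C)Cn1cnc2ncnc(N)c21` in this assay also gives only the limit > 30000 nM. The step that the two limits leave unreadable from compound 1 to compound 2 is therefore unreadable, both values sitting at the limit of > 30000 nM in this assay, at which 2 of the 2 values shown sit. Compound 3 `Nc1ncnc2ncn(CCCO)c12` differs from compound 2 by hydroxymethyl in place of hydroxy on a saturated chain carbon, two bonds along the chain from an aromatic nitrogen. Among the compounds with values here, no measured step bears on this change, and the two values shown give no direction. The step of a number no higher from compound 2 to compound 3 (the limit leaves the size open) is expected to remain at the limit. Compound 3 is estimated at 30000 nM, with a range from 10000 nM to 100000 nM.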

Compound 3, inhibition constant: > 30000 nM
Compound 3: only a limit was reported (the forecaster's own chance of this, stated with the estimate: 85%); the middle value sits exactly at the limit.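

Compound 1, compound 2 and compound 3 each give only a limit, so no step among them can be read: the limit of > 30000 nM in this assay, at which 3 of the 3 values shown sit.

The compounds shown leave open which chain on the shared core, if any, gives a measurable value in this assay.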